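Anilide ring substituent swap in a thiourea series

The source may report more compounds than this note shows. Statements on the series, on what has been measured and on what is new or still open speak of the compounds shown alone.

Measured so far:
compound 1 `Cc1ccc(NC(=S)NC(=O)c2cn(-c3ccccc3)nc2-c2ccc(F)cc2)cc1` – 5440 nM
compound 2 `O=C(NC(=S)Nc1ccc(F)cc1)c1cn(-c2ccccc2)nc1-c1ccccc1` – 6820 nM

In a functional assay on MCF7 cells (Homo sapiens) for inhibition, read by CCK-8 assay, with a stated time of 48 h (a higher number here means a weaker inhibitor, a lower number a stronger inhibitor), compound 2 gives 6820 nM, the highest of the two numbers; compound 1 gives 5440 nM, within the scatter of it, so no order can be claimed between them. Compound 3 `Cc1ccc(NC(=S)NC(=O)c2cn(-c3ccccc3)nc2-c2ccccc2)cc1` is not yet measured. It differs from compound 2 by methyl in place of fluoro on an aromatic carbon, para to a large group. Going by the values given here, no comparable step between measured compounds is available, so the size is expected to stay within the scatter, with no clear direction. Compound 3 is estimated at 6000 nM (range 3000 nM to 13000 nM), the step of a 1.1-fold lower number from compound 2 to compound 3 (0.06 log units; within the scatter) being expected as negligible.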

Compound 3, half-maximal inhibitory concentration: 5900 nM
The estimate for compound 3 lay 1.0-fold (0.01 log units) above the measured number; low and high end bracket the measured number.
By their numbers in this assay, from the lowest: compounds 1, 3 and 2 (each within the scatter of the next).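

In this assay, going by these compounds alone, the change from 4-fluorophenyl to 4-methylphenyl, para to a large group, gives a 1.2-fold lower number from compound 2 to compound 3 (0.06 log units; within the scatter) and is the first single change read at this position, with no shift beyond the scatter. Loss of a fluoro gives a 1.1-fold higher number from compound 1 to compound 3 (0.04 log units; within the scatter) and likewise shows no shift beyond the scatter. Nothing at hand bears on a cause for either result.

Only methyl and fluoro are compared at the position para to a large group. From the compounds shown here alone, whether an amine, a carboxylic acid or a longer chain there would move the number beyond the scatter stays open.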